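A few compounds are considered here, and "the series" means these few. Any claim that something is new, unique, unknown or untested is made for them only; others in the source may bear on it.

In a functional assay on NIH3T3 cells (Mus musculus) (a higher number here means that more compound is needed for the effect, a lower number that less compound is needed), compound 1 `CCC/C=C/C=C/c1cc(C#N)ccc1COC(c1ccc(C#N)cc1)c1cncn1C` gives 16.7 nM, and compound 2 `Cn1cncc1C(OCc1ccc(C#N)cc1C#Cc1ccc(C#N)cc1)c1ccc(C#N)cc1` gives 11.6 nM. Between these two lies a 1.4-fold lower number from compound 1 to compound 2 (0.16 log units; within the scatter), so swapping the hepta-1,3-dien-1-yl group for 2-(4-cyanophenyl)ethynyl left the reading within the scatter. Compound 3 `CCCCCCC#Cc1cc(C#N)ccc1COC(c1ccc(C#N)cc1)c1cncn1C` has no true number, only a limit of > 0.1 nM. The comparisons with it are therefore a step that the limit leaves unreadable from compound 1 to compound 3 and a step that the limit leaves unreadable from compound 2 to compound 3, and neither can serve as a guide to size.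

Compound 4 `Cn1cncc1C(OCc1ccc(C#N)cc1C#Cc1ccc([N+](=O)[O-])cc1)c1ccc(C#N)cc1` differs from compound 3 by 4-nitrophenyl in place of hexyl on a triple-bonded carbon. Among the measured compounds shown here, no measured compound carries 4-nitrophenyl. The closest guide is compound 2, which also has an aromatic ring on the triple-bonded carbon and reads 11.6 nM. For the measured compounds named here, with a 1.4-fold lower number from compound 1 to compound 2 (0.16 log units; within the scatter) as the only readable step, a value close to that of compound 2 is expected, with no firm direction from compound 3. The expected step is a step that the limit leaves unreadable from compound 3 to compound 4. Compound 4 is estimated at 12 nM, with an expected range of 3 nM to 45 nM.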

Compound 4, half-maximal effective concentration: 36 nM
For compound 4 the middle estimate is 3.0-fold (0.48 log units) below the measured one; low and high end bracket the measured number.
By their numbers in this assay, from the lowest: compounds 2 and 1 (each within the scatter of the next); then compound 4.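

In this assay, the group carried on the aromatic ring at the end of the triple bond does matter: nitro in place of cyano on an aromatic carbon gives a 3.1-fold higher number from compound 2 to compound 4 (0.49 log units; beyond the scatter). The earlier pair showed 2-(4-cyanophenyl)ethynyl and hepta-1,3-dien-1-yl reading alike, yet 2-(4-nitrophenyl)ethynyl in place of hepta-1,3-dien-1-yl gives a 2.2-fold higher number from compound 1 to compound 4 (0.33 log units; beyond the scatter), so an aromatic ring on the triple-bonded carbon does not by itself keep the number unchanged. The steps involving compound 3 cannot be read, because compound 3 carries only a limit: the limit of > 0.1 nM in this assay, at which 1 of the 4 values shown sits.

With only nitro and cyano compared on that ring, the compounds shown give no reason for the difference between them. From the compounds shown here alone, whether an amine or a carboxylic acid there would stay close to compound 2 remains open, as does whether a hexyl chain on the triple-bonded carbon reads differently from an aromatic ring.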